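The source may report more compounds than this note shows. Statements on the series, on what has been measured and on what is new or still open speak of the compounds shown alone.

Compound 1 `COc1ccc(N(C)c2nc(C)nc3ccccc23)cc1C(=O)OCCC[Se]C#N` gives 1180 nM in a functional assay on MDA-MB-231 cells (Homo sapiens) for inhibition, read by MTT assay, with a stated time of 48 h (a higher number here means a weaker inhibitor, a lower number a stronger inhibitor), the highest of the three numbers measured. Compound 2 `C[Se]c1ccc(N(C)c2nc(C)nc3ccccc23)cc1C` gives 7 nM in this assay, and compound 3 `Cc1nc(N(C)c2ccc([Se]C#N)c(F)c2)c2ccccc2n1` gives 6 nM; both lie far below compound 1, beyond the scatter. Compound 4 `COc1ccc(N(C)c2nc(C)nc3ccccc23)cc1C(=O)OCC[Se]C#N` has not yet been measured. It differs from compound 1 as follows: a group of 3 heavy atoms (1 carbon, 1 nitrogen, 1 selenium; no ring) in place of a group of 4 heavy atoms (2 carbon, 1 nitrogen, 1 selenium; no ring), on a saturated chain carbon, two bonds along the chain from an oxygen next to a carbonyl group. Going by the values given here, no pair of measured compounds shows a change of this kind, so there is nothing in the numbers to point in either direction; a small step in this assay is expected, of a size within the scatter. Compound 4 is expected to give 1000 nM in this assay, with a range from 350 nM to 3000 nM. This estimate means a 1.2-fold lower number from compound 1 to compound 4 (0.07 log units; within the scatter).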

Compound 4, half-maximal inhibitory concentration: 1480 nM
Beside the measured number, compound 4's estimate is 1.5-fold (0.17 log units) below it; measured number inside the range.
By their numbers in this assay, from the lowest: compounds 3 and 2 (each within the scatter of the next); then compounds 1 and 4 (each within the scatter of the next).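

Going by these compounds alone, replacing the group of 4 heavy atoms with the group of 3 heavy atoms on this saturated chain carbon gives a 1.3-fold higher number from compound 1 to compound 4 (0.10 log units; within the scatter) in this assay and is the first step measured at this position. Across this one change, the number stays within the scatter, so the two groups cannot be told apart in this assay. Nothing available bears on why this is so.

Going by these compounds, a longer chain at this position remains open, as does the effect of an amine or a carboxylic acid in place of this group.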